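Thiophene in place of an amino chain on the carbonyl

A few compounds are considered here, and "the series" means these few. Any claim that something is new, unique, unknown or untested is made for them only; others in the source may bear on it.

Compound 1 `O=C(c1ccc(Cl)cc1)c1ccn(-c2ccc3c(c2)B(O)OC3)c1` gives in an ADME assay on L929 cells (Mus musculus) for cytotoxicity, read by resazurin assay, with a stated time of 72 h (on this read-out lower numbers stand for stronger inhibition and higher numbers for weaker inhibition), a value of > 10 ug/mL, which is a limit of the assay and not a number.
Compound 2 `Nc1ccc(C(=O)c2ccn(-c3ccc4c(c3)B(O)OC4)c2)cc1` gives in this assay 3.9 ug/mL.
Compound 3 `NCCCC(=O)c1ccn(-c2ccc3c(c2)B(O)OC3)c1` gives in this assay > 10 ug/mL, again a limit of the assay.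

Going by the values given here, compound 3 thus sits at the limit of > 10 ug/mL in this assay, at which 2 of the 3 values shown sit, and the only readable step to it is an at least 2.5-fold higher number from compound 2 to compound 3 (0.40 log units; beyond the scatter); the step that the two limits leave unreadable from compound 1 to compound 3 cannot be sized, since both ends are limits.

Compound 4 `O=C(c1ccn(-c2ccc3c(c2)B(O)OC3)c1)c1cccs1` differs from compound 3 by thiophen-2-yl in place of 3-aminopropyl on a carbonyl carbon. The change brings back an aromatic ring on the carbonyl carbon, as in compound 1 and compound 2, but without the amino group that compound 2 carries. Among the measured steps, the one that moves the number beyond the scatter is an at least 2.5-fold lower number from compound 1 to compound 2 (0.40 log units; beyond the scatter), which goes with the amino group; compound 4 lacks that group.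

Compound 4 is therefore expected to sit at the limit like compound 1, with an estimate of 15 ug/mL and a range from 6 ug/mL to 40 ug/mL. The expected step that the limit leaves unreadable from compound 3 to compound 4 is thus one of no size beyond the scatter.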

Compound 4, half-maximal inhibitory concentration: > 10 ug/mL
Compound 4 ended at the assay's limit; the forecaster's own chance of this, stated with the estimate: 70%; the middle value is on the limit's open side.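

In this assay compound 4 gives > 10 ug/mL, which is a limit of the assay and not a number. Thiophen-2-yl in place of 4-aminophenyl on the carbonyl carbon gives an at least 2.5-fold higher number from compound 2 to compound 4 (0.40 log units; beyond the scatter), so an aromatic ring on this carbon, without an amino group, does not keep the lower number seen for compound 2. The steps joining compound 4 to compound 1 and to compound 3 cannot be read, and compound 2 remains the only compound with a measured number rather than a limit: the limit of > 10 ug/mL in this assay, at which 3 of the 4 values shown sit.

The compounds shown leave open how weak compound 1, compound 3 and compound 4 really are, so no order among these three can be given. They also leave open whether the amino group needs an aromatic ring to go with the lower number, since compound 3 carries its amino group on a chain and sits at the limit; an amine on the thiophene ring, or a hydroxyl group in place of the amino group on the phenyl ring, would bear on this.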